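This account rests on a few compounds, and the source may have more. Where it says the series, first, only, none or still open, it means among the compounds named here.

In an ADME assay on microsomes from liver (Canis lupus familiaris) for metabolic stability, with a stated time of 10 min (a higher number here means that more of the compound is left, a lower number that less of the compound is left), compound 1 `FC(F)(F)c1ccccc1-c1ccc2[nH]c(C3=NOC4(CCCCC4)C3)nc2c1` gives 71%, compound 2 `FC(F)(F)Oc1ccccc1-c1ccc2[nH]c(C3=NOC4(CCCCC4)C3)nc2c1` gives 81% and compound 3 `Fc1cccc(OC(F)(F)F)c1-c1ccc2[nH]c(C3=NOC4(CCCCC4)C3)nc2c1` gives 73%, so compound 2 stands within the scatter of both others. Trifluoromethoxy in place of trifluoromethyl gave a number 10 percentage points higher from compound 1 to compound 2 (within the scatter), and fluoro in place of hydrogen gave a number 8 percentage points lower from compound 2 to compound 3 (within the scatter). Compound 4 `CC(C)(O)c1ccccc1-c1ccc2[nH]c(C3=NOC4(CCCCC4)C3)nc2c1` carries 1-hydroxy-1-methylethyl in place of trifluoromethoxy on an aromatic carbon, ortho to a large group: 1-hydroxy-1-methylethyl in place of trifluoromethoxy on an aromatic carbon. Among the measured compounds shown here, no measured compound carries that group, so these two steps are only a loose guide. On those steps alone, the estimated change is a number 7 percentage points lower from compound 2 to compound 4 (within the scatter), with none beyond the scatter expected in this assay. Compound 4 is estimated at 74%, within an expected range of 56% to 90%.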

Compound 4, percent of the compound remaining: 4.4%
Estimate against measurement, compound 4: 69.6 percentage points above; measured number outside the range, below it.
By their numbers in this assay, from the lowest: compound 4; then compounds 1, 3 and 2 (each within the scatter of the next).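

At this position, on an aromatic carbon ortho to a large group, swapping trifluoromethyl for trifluoromethoxy had stayed within the scatter, yet 1-hydroxy-1-methylethyl gives a number 76.6 percentage points lower from compound 2 to compound 4 (beyond the scatter) in this assay, and a number 66.6 percentage points lower from compound 1 to compound 4 (beyond the scatter). Among the compounds shown here, the position is therefore not indifferent to the group it carries, as the earlier compounds had suggested. Nothing available bears on the reason for this drop.

Going by these compounds, whether the drop goes with the hydroxyl or with the branched carbon frame stays open. A tert-butyl group or the methyl ether of the same alcohol at this position would separate the two.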